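The source may hold more compounds than are shown below. What is called first, only, known or untested is meant among the compounds shown, and "the series" means these compounds.

Measured in a functional assay on MV4-11 cells (Homo sapiens) for antiproliferative activity, read by CellTiter-Glo, with a stated time of 72 h (on this read-out lower numbers stand for stronger inhibition of growth and higher numbers for weaker inhibition of growth), so far:
- compound 1 `CC(=O)N[C@H]1CC[C@H](Nc2cc(-c3csc(NCC4CCOCC4)n3)c(Cl)cn2)CC1` gives 3600 nM
- compound 2 `COCC(=O)N[C@H]1CC[C@H](Nc2cc(-c3csc(NCC4CCOCC4)n3)c(Cl)cn2)CC1` gives > 10000 nM, which is a limit
- compound 3 `COCCN[C@H]1CC[C@H](Nc2cc(-c3csc(NCC4CCOCC4)n3)c(Cl)cn2)CC1` gives 170 nM

Compound 3 holds the lower of the two exact numbers, as a 21-fold lower number from compound 1 to compound 3 (1.33 log units; beyond the scatter) shows. Compound 4 `CCOCCN[C@H]1CC[C@H](Nc2cc(-c3csc(NCC4CCOCC4)n3)c(Cl)cn2)CC1` differs from it by methyl in place of hydrogen on a saturated chain carbon bound to an oxygen on a saturated carbon, methoxy to ethoxy.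

For the measured compounds named here, no measured step changes this place. The nearest are a 21-fold lower number from compound 1 to compound 3 (1.33 log units; beyond the scatter) and an at least 58-fold lower number from compound 2 to compound 3 (1.76 log units; beyond the scatter), both large, which replace acetyl and (methoxymethyl)carbonyl on the amine nitrogen, and an at least 2.7-fold higher number from compound 1 to compound 2 (0.44 log units; beyond the scatter), which is at least modest. None of them transfers directly, so no step beyond the scatter is expected in this assay.

The expected step is a 1.2-fold higher number from compound 3 to compound 4 (0.07 log units; within the scatter), within the scatter.

For compound 4 the estimated value is 200 nM, with an expected range of 80 nM to 500 nM.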

Compound 4, concentration for 50% growth inhibition: 497 nM
Compound 4: middle estimate off by 2.5-fold (0.40 log units), on the low side; low and high end bracket the measured number.
By their numbers in this assay, from the lowest: compound 3; then compound 4; then compound 1. At a limit, above all of these: compound 2.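

In this assay, for the compounds shown here, methyl in place of hydrogen on a saturated chain carbon bound to an oxygen on a saturated carbon gives a 2.9-fold higher number from compound 3 to compound 4 (0.47 log units; beyond the scatter) and so shows that this place, untouched by the earlier steps, responds to a single added methyl. The 2-ethoxyethyl group on the amine nitrogen still holds an advantage, with a 7.2-fold lower number from compound 1 to compound 4 (0.86 log units; beyond the scatter) against acetyl and an at least 20-fold lower number from compound 2 to compound 4 (1.30 log units; beyond the scatter) against (methoxymethyl)carbonyl. The second of these rests on a limit for compound 2: the limit of > 10000 nM in this assay, at which 1 of the 4 values shown sits.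

Going by these compounds, whether a longer chain such as propoxy continues this trend stays open, as does the effect of a hydroxyl or an amine in place of the ether oxygen's alkyl group.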